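The compounds below may be only part of what the source reports. "The series", "measured", "known", "first", "only" and "open" are said of these compounds alone.

Measured so far in a functional assay on SGC-7901 cells (Homo sapiens) for cytotoxicity, read by MTT assay, with a stated time of 48 h; on this read-out lower numbers stand for stronger inhibition and higher numbers for weaker inhibition:
- compound 1 `O=c1ccoc2cc(OCc3cn(Cc4ccc(Br)cc4)nn3)ccc12` rests at the assay limit, > 100000 nM.
- compound 2 `O=c1ccoc2cc(OCc3cn(Cc4ccccc4F)nn3)ccc12` rests at the assay limit, > 100000 nM.

Compound 2 stands only at that limit; no number is known for it. The step that the two limits leave unreadable from compound 1 to compound 2 cannot be read, since both of its ends share (the limit of > 100000 nM in this assay, at which 2 of the 2 values shown sit). Compound 3 `N#Cc1ccc(Cn2cc(COc3ccc4c(=O)ccoc4c3)nn2)cc1` differs from compound 2 by 4-cyanophenyl in place of 2-fluorophenyl on a saturated chain carbon bound to an aromatic nitrogen. Among the compounds with values here, no measured step bears on this change with a readable size, and both measured compounds sit at the limit. The step that the limit leaves unreadable from compound 2 to compound 3 is therefore expected to be none the assay can resolve. Compound 3 is estimated at 150000 nM, within 50000 nM to 500000 nM, most likely again reported only as a limit.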

Compound 3, half-maximal inhibitory concentration: > 100000 nM
Compound 3 was reported as a limit; the forecaster's own chance of this, stated with the estimate: 80%; the middle value does not contradict the limit.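

In this assay, no step can be read among compound 1, compound 2 and compound 3, since all three rest at the same limit: the limit of > 100000 nM in this assay, at which 3 of the 3 values shown sit.

The compounds shown leave open how 4-bromophenyl, 2-fluorophenyl and 4-cyanophenyl rank, and whether any group in this place gives a readable value.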